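The source may report more compounds than this note shows. Statements on the series, on what has been measured and on what is new or still open speak of the compounds shown alone.

Compound 1: `CN1CCN(Cc2c[nH]c3ccc(F)cc23)CC1` gives > 1000 nM
Compound 2: `CNCCCc1c[nH]c2ccc(F)cc12` gives 26 nM
Compound 3: `CN1CCN(CCCc2c[nH]c3ccc(F)cc23)CC1` gives 310 nM

Of the compounds shown here, three sharing the same fluorinated core have been measured in an assay on isolated protein for inhibition of Myeloperoxidase (Homo sapiens); a higher number here means a weaker inhibitor, a lower number a stronger inhibitor. For compound 1 the result is a limit of the assay rather than a number (the limit of > 1000 nM in this assay, at which 1 of the 3 values shown sits). Among the two numbers that remain, compound 2 stands lowest; compound 3, with its cyclic amine on the same three-carbon chain, comes next, and its gap to compound 2 lies beyond the usual scatter of this assay.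

Compound 4, `NCCCCc1c[nH]c2ccc(F)cc12`, has not yet been measured in this assay. It holds the same atoms as compound 2, joined differently: aminomethyl in place of methylamino on a saturated chain carbon, three bonds along the chain from an aromatic carbon. Read one bond further out, the change is from 3-(methylamino)propyl to 4-aminobutyl; the methyl that sat on the nitrogen of compound 2 is instead added to the chain, leaving a primary amine at its end.

Among the measured compounds shown here, no measured pair shows this kind of change. Both compounds keep a basic nitrogen on a flexible chain, and the clear drop from compound 2 to compound 3 in this assay (310 nM) involves a much larger amine. The step from compound 2 to compound 4 is therefore expected to be small, a 1.7-fold higher number from compound 2 to compound 4 (0.24 log units; within the scatter), with a slight loss more likely than a gain. The estimate for compound 4 in this assay is 45 nM, within a range from 12 nM to 170 nM.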

Compound 4, half-maximal inhibitory concentration: 12 nM
For compound 4 the middle estimate is 3.8-fold (0.57 log units) above the measured one, and the stated range covers the measured number.
By their numbers in this assay, from the lowest: compound 4; then compound 2; then compound 3. At a limit, above all of these: compound 1.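

In this assay, moving the methyl off the nitrogen and into the chain, from 3-(methylamino)propyl to 4-aminobutyl, gives a 2.2-fold lower number from compound 2 to compound 4 (0.34 log units; beyond the scatter) as a modest step that lies beyond the usual scatter. The earlier compounds shown here did not show that this part of the chain responds to a change this small: both groups hold the same heavy atoms and the same count of hydrogen-bond donors and acceptors, and only the way they are joined differs. Nothing measured for these compounds gives a reason for the direction of this step.

The single step lengthens the chain and turns the end of it into a primary amine at once, so the compounds shown do not separate these two changes from each other; 4-(methylamino)butyl, which keeps the methyl on the nitrogen of the longer chain, would bear on that question. Also open, from the compounds shown here alone, is whether the trend continues with 5-aminopentyl, a still longer chain ending in a primary amine, or whether 3-aminopropyl, a shorter chain with the same kind of amine, holds up as well.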